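Hydrogen for Methyl on the Side-Chain Oxygen

The source may hold more compounds than are shown below. What is called first, only, known or untested is meant among the compounds shown, and "the series" means these compounds.

Compound 1 `COc1cccc2cc(C(=O)N[C@@H](CO)C(=O)O)c(=O)oc12`: 24%
Compound 2 `COCCNC(=O)c1cc2cccc(OC)c2oc1=O`: 18%

In an assay on HEK293 cells for displacement of a labelled ligand from adenosine receptor A2b (Homo sapiens), read by scintillation counting, with a stated time of 30 min, tested at 10 uM (on this read-out higher numbers stand for more inhibition at the one concentration tested (going by the name of the read-out) and lower numbers for less inhibition), compound 1 gives 24% and compound 2 gives 18%. Compound 2 sits within the scatter of compound 1, so the two cannot be told apart on these numbers. Compound 3 `COc1cccc2cc(C(=O)NCCO)c(=O)oc12` differs from compound 2 by hydrogen in place of methyl on an oxygen on a saturated carbon. Among the compounds with values here, the only measured step, a number 6 percentage points lower from compound 1 to compound 2 (within the scatter), exchanged the whole group on the amide nitrogen and stayed within the scatter; no measured step removes a methyl from an oxygen. Compound 3 is therefore expected to show a number 2 percentage points higher from compound 2 to compound 3 (within the scatter), a change not beyond the scatter. For compound 3 the estimate is 20%, in the range 5% to 38%.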

Compound 3, a percentage reported as inhibition, at one concentration (the size of the read-out at that concentration, not a potency): 7%
Compound 3: middle estimate off by 13 percentage points, on the high side, and the stated range covers the measured number.
By their numbers in this assay, from the lowest: compound 3; then compounds 2 and 1 (each within the scatter of the next).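

Hydrogen in place of methyl on the side-chain oxygen gives a number 11 percentage points lower from compound 2 to compound 3 (beyond the scatter) and is the first step here to pass the scatter, so the far end of this chain responds to the loss of one methyl. Hydrogen in place of carboxy gives a number 17 percentage points lower from compound 1 to compound 3 (beyond the scatter) and also passes the scatter, which leaves compound 3 below both others. Nothing available explains either step.

On these data alone, it remains open how an amine or a longer chain ending in hydroxy would read at this position.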